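Azide, triazole and amide at one ring carbon

The source may hold more compounds than are shown below. What is called first, only, known or untested is meant among the compounds shown, and "the series" means these compounds.

Values in a functional assay on SMMC-7721 cells (Homo sapiens) for antiproliferative activity, read by MTT assay, with a stated time of 48 h (a higher number here means a weaker inhibitor, a lower number a stronger inhibitor), for the measured compounds:
- compound 1 `COC/C1=C/C[C@](C)(CCC=C(C)C)/C=C/[C@@H](OC(=O)C=C(C)C)[C@](C)(O)/C=C/C1=O` gives 11000 nM
- compound 2 `CC(C)=CCC[C@]1(C)/C=C/[C@@H](OC(=O)C=C(C)C)[C@](C)(O)/C=C/C(=O)/C(CN=[N+]=[N-])=C\C1` gives 3080 nM
- compound 3 `CC(C)=CCC[C@]1(C)/C=C/[C@@H](OC(=O)C=C(C)C)[C@](C)(O)/C=C/C(=O)/C(Cn2cc(CO)nn2)=C\C1` gives 3560 nM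

Compound 3 cannot be separated from compound 2, with a 1.2-fold higher number from compound 2 to compound 3 (0.06 log units; within the scatter). It does stand clear of compound 1, with a 3.1-fold lower number from compound 1 to compound 3 (0.49 log units; beyond the scatter).

The next member is compound 4 `CC(C)=CCC[C@]1(C)/C=C/[C@@H](OC(=O)C=C(C)C)[C@](C)(O)/C=C/C(=O)/C(C(=O)N(C)C)=C\C1`, in which dimethylcarbamoyl takes the place of (4-(hydroxymethyl)-1H-1,2,3-triazol-1-yl)methyl on a double-bonded ring carbon: dimethylcarbamoyl in place of (4-(hydroxymethyl)-1H-1,2,3-triazol-1-yl)methyl on a double-bonded ring carbon.

Among the measured compounds shown here, no measured step covers this change directly. All three measured steps swap a group on a saturated chain carbon bound to a double-bonded ring carbon, whereas dimethylcarbamoyl sits on the double-bonded ring carbon itself. They still give the nearest guide to size. The change to azido is a 3.6-fold lower number from compound 1 to compound 2 (0.55 log units; beyond the scatter), which is modest, and the step to compound 3 from compound 1 is of similar size. Compound 1 at 11000 nM shows that the number can sit higher with another group in this region. A modest step towards a higher number in this assay is therefore expected, with wide uncertainty.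

The expected step is a 1.7-fold higher number from compound 3 to compound 4 (0.23 log units; within the scatter). The estimated value for compound 4 is 6000 nM, with an expected range from 2500 nM to 15000 nM.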

Compound 4, half-maximal inhibitory concentration: 3670 nM
Compound 4: middle estimate off by 1.6-fold (0.21 log units), on the high side; low and high end bracket the measured number.
By their numbers in this assay, from the lowest: compounds 2, 3 and 4 (each within the scatter of the next); then compound 1.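

In this assay, dimethylcarbamoyl on the double-bonded ring carbon cannot be separated from the (4-(hydroxymethyl)-1H-1,2,3-triazol-1-yl)methyl group it replaces, with a 1.0-fold higher number from compound 3 to compound 4 (0.01 log units; within the scatter), or from azidomethyl, with a 1.2-fold higher number from compound 2 to compound 4 (0.08 log units; within the scatter). This position therefore accepts a group with no ring and a carbonyl carbon bound directly to the ring carbon, as well as the two groups joined through a saturated chain carbon, with no separation among compound 2, compound 3 and compound 4. Methoxymethyl remains the only group shown that stands apart from the others, and the amide shares that separation, with a 3.0-fold lower number from compound 1 to compound 4 (0.48 log units; beyond the scatter) (modest). No measurement available gives a reason for this separation or for the lack of one among the other three groups.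

Still open, from the compounds shown here alone, is whether a primary amine or a carboxylic acid on this ring carbon, or a longer chain carrying the amide, would stay with compound 2, compound 3 and compound 4 or move towards compound 1. Every compound shown also carries the ((2-methylprop-1-en-1-yl)carbonyl)oxy group, so it remains open whether the same pattern holds with a different group in its place.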